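A few compounds are considered here, and "the series" means these few. Any claim that something is new, unique, unknown or untested is made for them only; others in the source may bear on it.

Compound 3 `O=C1O[C@@H](Cn2ccnc2)CN1c1ccc(-n2cc(-c3ccccn3)cn2)c(F)c1` stands in an ADME assay on HEK293-A cells (Homo sapiens) for cytotoxicity, read by MTT assay, with a stated time of 48 h (on this read-out lower numbers stand for stronger inhibition and higher numbers for weaker inhibition), at a limit: compound 3 gives > 400 ug/mL, a limit of the measurement and not a number. The two neighbouring compounds sit at the same limit. Compound 1 `O=C1O[C@@H](CN2CCC(O)CC2)CN1c1ccc(-n2cc(-c3ccccn3)cn2)c(F)c1` gives > 400 ug/mL in this assay, which is a limit. Compound 2 `O=C1CNC(=O)N1C[C@H]1CN(c2ccc(-n3cc(-c4ccccn4)cn3)c(F)c2)C(=O)O1` gives > 400 ug/mL in this assay, again a limit. This is the limit of > 400 ug/mL in this assay, at which 3 of the 3 values shown sit, so none of the three values carries a number that could be compared. The steps between these compounds are accordingly unreadable: a step that the two limits leave unreadable from compound 1 to compound 2, a step that the two limits leave unreadable from compound 1 to compound 3 and a step that the two limits leave unreadable from compound 2 to compound 3. Compound 4 `O=C1O[C@@H](CSc2cccs2)CN1c1ccc(-n2cc(-c3ccccn3)cn2)c(F)c1` differs from compound 3 by (thiophen-2-yl)sulfanyl in place of 1H-imidazol-1-yl on a saturated chain carbon bound to a saturated ring carbon. Going by the values given here, no measured step of readable size bears on this change; all three measured steps end at the limit and therefore give neither a size nor a direction. Among the compounds with values here, what the measured compounds show is only that every variation so far at this position has remained at the limit. For compound 4, the estimated step in this assay is a number no higher from compound 3 to compound 4 (the limit leaves the size open). Compound 4 is expected in this assay at 400 ug/mL, within 150 ug/mL to 800 ug/mL, with the greater chance that this assay again reports only a limit rather than a number.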

Compound 4, half-maximal inhibitory concentration: > 400 ug/mL
Compound 4 gave a limit, no number (the forecaster's own chance of this, stated with the estimate: 70%); the middle value sits exactly at the limit.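

In this assay compound 4 gives > 400 ug/mL, a limit and not a number. Going by these compounds alone, no step from compound 1, compound 2 or compound 3 to compound 4 can be read: the limit of > 400 ug/mL in this assay, at which 4 of the 4 values shown sit. The compounds shown leave open how far each lies from that limit, and whether any group on this saturated chain carbon gives a measurable value.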